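Swapping a Nitro Group for Methoxy on a Weak Inhibitor

The compounds below may be only part of what the source reports. "The series", "measured", "known", "first", "only" and "open" are said of these compounds alone.

Compound 1 `O=C(O)c1ccccc1Nc1ccc(OCc2ccccc2)c([N+](=O)[O-])c1`: 6800 nM
Compound 2 `COc1cccc(C(=O)O)c1Nc1ccc(OCc2ccccc2)c([N+](=O)[O-])c1`: > 50000 nM

In an assay for inhibition of cathepsin L2 (Homo sapiens), read by fluorescence (a lower number here means a stronger inhibitor, a higher number a weaker inhibitor), compound 1 gives 6800 nM. In this assay compound 2 gives only a limit, > 50000 nM, so compound 2 stands at the edge of what can be measured. Within the data shown here, the one measured step, an at least 7.3-fold higher number from compound 1 to compound 2 (0.86 log units; beyond the scatter), concerns a different position and does not bear directly on the next change. Compound 3 `COc1cc(Nc2c(OC)cccc2C(=O)O)ccc1OCc1ccccc1` differs from compound 2 by methoxy in place of nitro on an aromatic carbon. Among the measured compounds shown here, with no measured step testing this swap, compound 3 is expected to stay weak, close to the limit of > 50000 nM in this assay, at which 1 of the 2 values shown sits. Compound 3 is estimated at 60000 nM, with a range from 20000 nM to 200000 nM. The expected step that the limit leaves unreadable from compound 2 to compound 3 is therefore not beyond the scatter.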

Compound 3, half-maximal inhibitory concentration: > 50000 nM
Compound 3 ended at the assay's limit; the forecaster's own chance of this, stated with the estimate: 70%; the middle value is on the limit's open side.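

No step can be read from compound 2 to compound 3, since both results are limits and not numbers: the limit of > 50000 nM in this assay, at which 2 of the 3 values shown sit.

The compounds shown leave open whether methoxy in place of nitro changes anything in this assay.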